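The source may report more compounds than this note shows. Statements on the series, on what has been measured and on what is new or still open speak of the compounds shown alone.

Compound 1 `C=CC(=O)Nc1cc(Nc2ncc3ncn(-c4ccc(C)cc4)c3n2)c(OC)cc1N(C)CCN(C)C`: 9230 nM
Compound 2 `C=CC(=O)Nc1cc(Nc2ncc3ncn(-c4ccc(CC)cc4)c3n2)c(OC)cc1N(C)CCN(C)C`: 8180 nM

In an ADME assay on HT-29 cells (Homo sapiens) for cytotoxicity, read by MTT assay, with a stated time of 72 h (a lower number here means a stronger inhibitor, a higher number a weaker inhibitor), compound 2 gives 8180 nM, and compound 1 sits within the scatter of it, so the two are not distinguished. Compound 3 `C=CC(=O)Nc1cc(Nc2ncc3ncn(-c4ccc(Cl)cc4)c3n2)c(OC)cc1N(C)CCN(C)C` differs from compound 2 by chloro in place of ethyl on an aromatic carbon. Among the compounds with values here, the only measured step, a 1.1-fold lower number from compound 1 to compound 2 (0.05 log units; within the scatter), concerns a change on the saturated chain and not a chloro on the aromatic carbon, so it offers no direction for this change, and it was itself within the scatter. Nothing measured points to a step beyond the scatter. Compound 3 is therefore expected at 8500 nM, with a range of 4000 nM to 18000 nM. The expected step is a 1.0-fold higher number from compound 2 to compound 3 (0.02 log units; within the scatter).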

Compound 3, half-maximal inhibitory concentration: 7690 nM
Compound 3: middle estimate off by 1.1-fold (0.04 log units), on the high side; measured number inside the range.
By their numbers in this assay, from the lowest: compounds 3, 2 and 1 (each within the scatter of the next).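

In this assay, chloro in place of ethyl on the aromatic carbon (a 1.1-fold lower number from compound 2 to compound 3 (0.03 log units; within the scatter)) and chloro in place of methyl (a 1.2-fold lower number from compound 1 to compound 3 (0.08 log units; within the scatter)) leave the three compounds undistinguished. The earlier pair compared only two saturated chains at this position, whereas these steps show that a chlorine atom there also gives no separation from either chain. No measurement bears on why these numbers stay together. From the compounds shown here alone, whether an amine, a carboxylic acid or a longer chain at this place would give a step beyond the scatter remains open.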